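A few compounds are considered here, and "the series" means these few. Any claim that something is new, unique, unknown or untested is made for them only; others in the source may bear on it.

Working notes on the series in a functional assay on HCT-116 cells (Homo sapiens) for antiproliferative activity, read by MTT assay, with a stated time of 48 h; on this read-out higher numbers stand for weaker inhibition and lower numbers for stronger inhibition. Compound 1 (`COc1cc(C(=O)/C=C/c2ccc(OCCCC(=O)NCCCCN(CCCN)CCCCN)cc2)cc(OC)c1OC`) gives 29200 nM, and compound 3 (`COc1cc(C(=O)/C=C/c2ccc(OCCCC(=O)NCCCCNCCCN)cc2)cc(OC)c1OC`) gives 20000 nM. Going by the values given here, these are the only two numerical values so far, and the comparison is a 1.5-fold lower number from compound 1 to compound 3 (0.16 log units; within the scatter), so compound 3 stands level with compound 1. Compound 2 (`COc1cc(C(=O)/C=C/c2ccc(OCCCC(=O)NCCCNCCCCN)cc2)cc(OC)c1OC`) reads > 100000 nM, which is a limit of the assay.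

The next change, leading to compound 4 (`COc1cc(C(=O)/C=C/c2ccc(OCCCC(=O)NCCCCN(CCCN)CCCCNCCCN)cc2)cc(OC)c1OC`), is 4-((3-aminopropyl)amino)butyl in place of hydrogen on an amine nitrogen. Among the compounds with values here, the closest precedent is substitution on the same amine nitrogen, where 4-aminobutyl in compound 1 takes the place of that hydrogen: a 1.5-fold lower number from compound 1 to compound 3 (0.16 log units; within the scatter). The larger steps, an at least 3.4-fold higher number from compound 1 to compound 2 (0.53 log units; beyond the scatter) and an at least 5.0-fold lower number from compound 2 to compound 3 (0.69 log units; beyond the scatter), both involve compound 2 and alter the chain elsewhere, so they bear less directly on this change. The entering group is larger than 4-aminobutyl, so the precedent is only partial and the range stays wide.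

No shift beyond the scatter is expected in this assay, and the expected step is a 1.1-fold higher number from compound 3 to compound 4 (0.04 log units; within the scatter). For compound 4 the estimated value is 22000 nM, with an expected range of 8000 nM to 60000 nM.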

Compound 4, half-maximal inhibitory concentration: 75400 nM
For compound 4 the middle estimate is 3.4-fold (0.53 log units) below the measured one; the whole stated range lies below it.
By their numbers in this assay, from the lowest: compounds 3 and 1 (each within the scatter of the next); then compound 4. At a limit, above all of these: compound 2.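

On the amine nitrogen carrying two saturated chain carbons, compound 4 shows that the substituent can matter in this assay: 4-((3-aminopropyl)amino)butyl in place of hydrogen gives a 3.8-fold higher number from compound 3 to compound 4 (0.58 log units; beyond the scatter), whereas the 4-aminobutyl of compound 1 stayed within the scatter of hydrogen. Adding 3-aminopropyl to that 4-aminobutyl arm also moves the number beyond the scatter, with a 2.6-fold higher number from compound 1 to compound 4 (0.41 log units; beyond the scatter), so the weakening appears only with the longer arm. Nothing measured here accounts for this shift.

The compounds shown leave open whether the added amine or the added chain length carries the step. A plain octyl chain or a 4-hydroxybutyl group on this nitrogen would help separate the two.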